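A few compounds are considered here, and "the series" means these few. Any claim that something is new, unique, unknown or untested is made for them only; others in the source may bear on it.

Series notes. For the measured compounds named here, in a physicochemical assay for lipophilicity, read by HPLC, at pH 7.5 (on this read-out lower numbers stand for lower lipophilicity and higher numbers for higher lipophilicity), three compounds have numbers so far. Compound 1 `CC[C@@H](Nc1c(C#N)c(-c2ccc(Br)cc2)nc2cnccc12)C(=O)O` gives 1.6 in this assay, compound 2 `CC[C@@H](Nc1c(C#N)c(-c2ccc(-c3ccccc3N(C)C)cc2)nc2cnccc12)C(N)=O` gives 3.2, and compound 3 `CCOc1ccccc1-c1ccc(-c2nc3cnccc3c(N)c2C#N)cc1` gives 3. Compound 2 holds the highest of the three numbers; compound 3 sits nearest and within the scatter of it, while compound 1 lies furthest, beyond the scatter.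

Compound 4 `CC[C@@H](Nc1c(C#N)c(-c2ccc(-c3ccccc3Cl)cc2)nc2cnccc12)C(N)=O` has not been measured. It differs from compound 2 in one place: chloro in place of dimethylamino on an aromatic carbon. Going by the values given here, no measured pair shows this change, so no step for it is known from the data.

The expectation is a small rise from compound 2, a number 0.30 log units higher from compound 2 to compound 4 (within the scatter), near the edge of the scatter. Compound 4 is estimated at 3.5 in this assay, with a range from 3.1 to 3.9.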

Compound 4, distribution coefficient: 2.9
Beside the measured number, compound 4's estimate is 0.60 log units above it, outside the stated range (below it).
By their numbers in this assay, from the lowest: compound 1; then compounds 4, 3 and 2 (each within the scatter of the next).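

In this assay, chloro in place of dimethylamino on an aromatic carbon ortho to a large group gives a number 0.30 log units lower from compound 2 to compound 4 (within the scatter) as the first step read at this place in the series. The two compounds therefore stay unseparated, even though the change takes away a larger group with a hydrogen-bond acceptor and puts in a single chlorine. No supporting data bear on why the two numbers stand this close.

As far as these compounds go, whether fluoro, methoxy or a primary amine at this place would also stay within the scatter remains open. So does the effect of moving chloro to another carbon of that ring.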